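Methoxy in place of chloro: compound 3 to compound 4

A few compounds are considered here, and "the series" means these few. Any claim that something is new, unique, unknown or untested is made for them only; others in the source may bear on it.

Compound 3 `O=C(Nc1cc(Cl)cc2cccnc12)c1ncccn1` in a functional assay on BXPC-3 cells (Homo sapiens) for inhibition, read by MTT assay, with a stated time of 72 h (on this read-out higher numbers stand for weaker inhibition and lower numbers for stronger inhibition), gives only a limit, > 10000 nM. Compound 2 `O=C(Nc1cc(F)cc2cccnc12)c1ncccn1` likewise gives only a limit in this assay, > 10000 nM. The step that the two limits leave unreadable from compound 2 to compound 3 is therefore not readable, as noted in the limit of > 10000 nM in this assay, at which 2 of the 3 values shown sit. Within the data shown here, compound 1 `COc1cc(NC(=O)c2cnc(C)cn2)c2ncccc2c1`, with methoxy at the same place but a different amide, gives 6700 nM in this assay; no step links it to compound 3. The change to compound 4 `COc1cc(NC(=O)c2ncccn2)c2ncccc2c1` is methoxy in place of chloro on an aromatic carbon. Among the measured compounds shown here, no measured step bears on this change; the single step present is unreadable, so no direction beyond the scatter can be set. Compound 4 is estimated at 12000 nM, range 5000 nM to 30000 nM. The expected step is a step that the limit leaves unreadable from compound 3 to compound 4, and a limit is again likely.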

Compound 4, half-maximal inhibitory concentration: > 10000 nM
Compound 4: no number, only a limit (the forecaster's own chance of this, stated with the estimate: 60%); the middle value is on the limit's open side.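

In this assay compound 4 gives only a limit, > 10000 nM. Methoxy now joins fluoro and chloro at this position without yielding a number, so the steps among compound 2, compound 3 and compound 4 cannot be read: the limit of > 10000 nM in this assay, at which 3 of the 4 values shown sit. Pyrimidin-2-yl in place of 5-methylpyrazin-2-yl on the carbonyl carbon gives an at least 1.4-fold higher number from compound 1 to compound 4 (0.17 log units; that floor lies within the scatter), so this amide change is not separated from the scatter.

As far as these compounds go, whether an amine or a carboxylic acid at this position would give a number within the assay's range stays open. Also open, from the compounds shown here alone, is how 5-methylpyrazin-2-yl behaves with fluoro or chloro on the shared core.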